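Halogen swap on the aryl ring, microsomal clearance notes

The compounds below may be only part of what the source reports. "The series", "measured", "known", "first", "only" and "open" are said of these compounds alone.

Measured so far:
compound 1, `O=C(COCc1ccncc1)N1CCN(c2ccc(Cl)cc2F)CC1`, 38 mL.min-1.g-1
compound 2, `O=C(COCc1ccncc1)N1CCN(c2ccc(F)cc2F)CC1`, 22 mL.min-1.g-1
compound 3, `O=C(COCc1ccncc1)N1CCC(c2ccc(F)cc2Cl)CC1`, 56 mL.min-1.g-1

All three numbers come from an in vitro ADME assay on microsomes from liver (Homo sapiens) for metabolic stability; on this read-out lower numbers stand for slow clearance and higher numbers for fast clearance. Compound 1 and compound 2 share one core; compound 3 sits on a different core, and the difference between the two cores is not broken down here. Compound 4, `O=C(COCc1ccncc1)N1CCC(c2ccc(Cl)cc2Cl)CC1`, is not yet measured.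

From compound 2 to compound 1 the change is chloro in place of fluoro on an aromatic carbon, with the step of a 1.7-fold higher number from compound 2 to compound 1 (0.24 log units; within the scatter). From compound 3 to compound 4 the change is chloro in place of fluoro on an aromatic carbon. It is the same kind of change, not the same: in compound 1 the new chloro stands meta to a fluoro group, in compound 4 meta to a chloro group, on the other core.

Resting on that earlier step and on compound 3 at 56 mL.min-1.g-1, the expected step is a 1.4-fold higher number from compound 3 to compound 4 (0.15 log units; within the scatter) in this assay. Compound 4 is estimated at 80 mL.min-1.g-1, between 45 mL.min-1.g-1 and 150 mL.min-1.g-1.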

Compound 4, intrinsic clearance in microsomes: 96 mL.min-1.g-1
Compound 4: middle estimate off by 1.2-fold (0.08 log units), on the low side; the measured number falls inside the stated range.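

In this assay chloro in place of fluoro on an aromatic carbon gives a 1.7-fold higher number from compound 3 to compound 4 (0.23 log units; within the scatter) on the core of compound 3, and this step matches the one on the core of compound 1: the same change on two cores in this assay, a 1.7-fold higher number (0.24 log units; within the scatter) from compound 2 to compound 1 and a 1.7-fold higher number (0.23 log units; within the scatter) from compound 3 to compound 4, 1.0-fold (0.00 log units) apart, within the scatter of two such steps

The swap therefore carries across these two cores with no visible difference in step size. Each step lies within the scatter on its own, however, so the pair does not establish a real effect of the swap on clearance, and two cores say nothing about a third.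

The compounds shown leave open how bromo, methyl or a nitrile on the aryl ring would read on either core. Also open, going by these compounds, is whether an amine or a carboxylic acid on the aryl ring would follow the same course.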